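Melanocortin receptor 4 intrinsic activity: chain isomer of compound 2

A few compounds are considered here, and "the series" means these few. Any claim that something is new, unique, unknown or untested is made for them only; others in the source may bear on it.

Measured so far:
compound 1 `Cc1ccc(N2CCN(C(=O)[C@@H]3CN(C4CCOCC4)C[C@H]3c3ccc(Cl)cc3)CC2)c([C@@H](NC(=O)[C@H](C)N)C(C)C)c1` gives 38% in a functional assay on CHO cells with Melanocortin receptor 4 (Homo sapiens) as the target, read by cAMP accumulation; a lower number here means a smaller maximal response, a higher number a larger maximal response
compound 2 `Cc1ccc(N2CCN(C(=O)[C@@H]3CN(C4CCOCC4)C[C@H]3c3ccc(Cl)cc3)CC2)c([C@@H](NC(=O)[C@@H](C)N)C(C)C)c1` gives 56% in this assay

Compound 2 stands highest of the two measured values in this assay; compound 1 lies a number 18 percentage points higher from compound 1 to compound 2 (beyond the scatter) below it, a difference resting on (the fact that compounds 1 and 2 differ only in the configuration as drawn).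

Compound 3 `Cc1ccc(N2CCN(C(=O)[C@@H]3CN(C4CCOCC4)C[C@H]3c3ccc(Cl)cc3)CC2)c([C@@H](NC(=O)CCN)C(C)C)c1` is not yet measured. It differs from compound 2 by 2-aminoethyl in place of 1-aminoethyl on a carbonyl carbon, so the stereocentre whose configuration separated compound 1 from compound 2 is gone. The step from compound 1 to compound 2 bears on this change: it was modest, and a shift of the same group without that stereocentre is expected to fall between the two measured values. Compound 3 is therefore expected at 45% in this assay, within 25% to 65%, meaning an expected step of a number 11 percentage points lower from compound 2 to compound 3 (beyond the scatter).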

Compound 3, intrinsic activity: the largest response reached, in percent of the reference agonist's: 107%
Compound 3: the middle estimate sits 62 percentage points below what was measured; the whole stated range lies below it.
By their numbers in this assay, from the lowest: compound 1; then compound 2; then compound 3.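

In this assay, 2-aminoethyl in place of 1-aminoethyl on the carbonyl carbon gives a number 51 percentage points higher from compound 2 to compound 3 (beyond the scatter) and a number 69 percentage points higher from compound 1 to compound 3 (beyond the scatter). The position therefore tolerates a large rise in maximal response, and compound 3 reaches 107% without any stereocentre on this chain. In these three compounds, where the amine sits on the chain counts for more than the configuration, which alone separates the two 1-aminoethyl compounds: the fact that compounds 1 and 2 differ only in the configuration as drawn

As far as these compounds go, whether a longer chain such as 3-aminopropyl keeps this maximal response remains open. Potency at this receptor also remains open.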